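Nitro for Cyano on a Benzothiazole Amide Series

The source may report more compounds than this note shows. Statements on the series, on what has been measured and on what is new or still open speak of the compounds shown alone.

Compound 1, `Cc1cc(C)c2sc(NC(=O)c3ccc(C#N)cc3)nc2c1`, was examined in a functional assay on MDA-MB-231 cells (Homo sapiens) for antiproliferative activity, read by sulforhodamine B assay (on this read-out higher numbers stand for weaker inhibition of growth and lower numbers for stronger inhibition of growth), where compound 1 gives 0.48 ug/mL. Compound 2, `COc1cccc2sc(NC(=O)c3ccc(C#N)cc3)nc12`, carries a different core; the difference between the two cores is not broken down here. In this assay compound 2 reaches only a limit of > 10 ug/mL. Compound 3, `COc1cccc2sc(NC(=O)c3ccc([N+](=O)[O-])cc3)nc12`, differs from compound 2 by nitro in place of cyano on an aromatic carbon, and compound 3 likewise reaches only a limit of > 10 ug/mL. The step that the two limits leave unreadable from compound 2 to compound 3 is therefore unreadable, because of the limit of > 10 ug/mL in this assay, at which 2 of the 3 values shown sit.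

Compound 4, `Cc1cc(C)c2sc(NC(=O)c3ccc([N+](=O)[O-])cc3)nc2c1`, differs from compound 1 by the same change, (nitro in place of cyano on an aromatic carbon). Since the measured pair gives no readable size for this change, the expectation for compound 4 rests on compound 1 alone, with a step of a 1.7-fold higher number from compound 1 to compound 4 (0.22 log units; within the scatter) expected to stay modest. Compound 4 is estimated at 0.8 ug/mL, between 0.25 ug/mL and 3 ug/mL.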

Compound 4, concentration for 50% growth inhibition: 0.29 ug/mL
Compound 4: the middle estimate sits 2.8-fold (0.44 log units) above what was measured, and the stated range covers the measured number.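

In this assay, nitro in place of cyano on the core of compound 1 gives a 1.7-fold lower number from compound 1 to compound 4 (0.22 log units; within the scatter), so on this core the read-out does not separate the two groups. This one readable step belongs to a single core and shows nothing about how the change behaves on another. On the core of compound 2, the same change from compound 2 to compound 3 cannot be read, because both compounds stand at a limit and not at a number: the limit of > 10 ug/mL in this assay, at which 2 of the 4 values shown sit.

The compounds shown leave open how other groups in the same place on the aromatic ring, such as an amine or a carboxylic acid, would compare with cyano and nitro on the core of compound 1. As far as these compounds go, whether any such group would give a readable number on the core of compound 2 also stays open.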